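The source may report more compounds than this note shows. Statements on the series, on what has been measured and on what is new or still open speak of the compounds shown alone.

Working notes on the ester series sharing the core of compound 1 `CCOc1cc(NC(=O)C2(NC(=O)c3ccc4c(C5CCCC5)c(-c5ncc(Cl)cn5)n(C)c4c3)CCC2)ccc1/C=C/C(=O)OCOP(=O)(O)O`.

Within the data shown here, in an ADME assay (liver) for pharmacokinetics, with Liver microsome (Homo sapiens) as the target, using microsomes (a higher number here means that the compound lasts longer, a lower number that the compound disappears faster), compound 1 gives 0.167 h, the only actual number among the three values so far. Compound 2 `CCOC(=O)/C=C/c1ccc(NC(=O)C2(NC(=O)c3ccc4c(C5CCCC5)c(-c5ncc(Cl)cn5)n(C)c4c3)CCC2)cc1OCC` in this assay reaches only the limit > 5 h. Compound 3 `CCOc1cc(NC(=O)C2(NC(=O)c3ccc4c(C5CCCC5)c(-c5ncc(Cl)cn5)n(C)c4c3)CCC2)ccc1/C=C/C(=O)OCC(C)C` in this assay likewise reaches only the limit > 5 h. The two steps from compound 1 are both large: an at least 29-fold higher number from compound 1 to compound 2 (1.47 log units; beyond the scatter), and an at least 29-fold higher number from compound 1 to compound 3 (1.47 log units; beyond the scatter). Between the two ethyl-and-isobutyl esters nothing can be read, since a step that the two limits leave unreadable from compound 2 to compound 3; here the limit of > 5 h in this assay, at which 2 of the 3 values shown sit, is all that is known.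

Compound 4 `CCOc1cc(NC(=O)C2(NC(=O)c3ccc4c(C5CCCC5)c(-c5ncc(Cl)cn5)n(C)c4c3)CCC2)ccc1/C=C/C(=O)OCC(=O)N1CCCC1` is the next member to go into this assay. Its change from compound 1 is a group of 7 heavy atoms (5 carbon, 1 nitrogen, 1 oxygen; one five-membered non-aromatic ring with 1 hetero atom) in place of a group of 5 heavy atoms (4 oxygen, 1 phosphorus; no ring), on a saturated chain carbon bound to an oxygen next to a carbonyl group. Both measured steps that bear on it replace the same group on the same carbon and both run upward by a large amount, so the step from compound 1 to compound 4 is expected to run upward well beyond the scatter, about an 18-fold higher number from compound 1 to compound 4 (1.25 log units; beyond the scatter). For compound 4 the half-life in this assay is therefore estimated at 3 h, within a range of 0.8 h to 5 h, with a fair chance that only a limit is returned.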

Compound 4, half-life: 1.65 h
Beside the measured number, compound 4's estimate is 1.8-fold (0.26 log units) above it; measured number inside the range.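

In this assay, the saturated chain carbon bound to an oxygen next to a carbonyl group now gives a step that can be sized on both sides, not only from below: a 9.9-fold higher number from compound 1 to compound 4 (0.99 log units; beyond the scatter). The (pyrrolidin-1-yl)carbonyl group also falls short of the isopropyl and methyl groups in the same place, with an at least 3.0-fold lower number from compound 3 to compound 4 (0.48 log units; beyond the scatter) and an at least 3.0-fold lower number from compound 2 to compound 4 (0.48 log units; beyond the scatter), so removing the phosphorus-bearing group does not alone settle the outcome, and what enters in its place matters. Both of these steps are minimum sizes, as compound 2 and compound 3 each stand at a limit: the limit of > 5 h in this assay, at which 2 of the 4 values shown sit.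

The compounds shown do not separate the contribution of the pyrrolidine ring from that of its carbonyl; an open-chain diethylamide or a morpholine amide on this carbon would bear on that. The step between compound 2 and compound 3 still cannot be read.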